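The compounds below may be only part of what the source reports. "The series", "measured", "known", "first", "only" and "open" are said of these compounds alone.

Measured in a functional assay on HT-29 cells (Homo sapiens) for cytotoxicity, read by MTT assay, with a stated time of 72 h; on this read-out higher numbers stand for weaker inhibition and lower numbers for stronger inhibition:
Compound 1 `COc1cc2c(Oc3ccc(NC(=O)c4cn(-c5ccccc5C)nn4)cc3F)ccnc2cc1OCCCN1CCCCC1` gives 1340 nM.
Compound 2 `COc1cc2c(Oc3ccc(NC(=O)c4cn(-c5ccccc5)nn4)cc3F)ccnc2cc1OCCCN1CCC(C)CC1` gives 190 nM.
Compound 3 `COc1cc2c(Oc3ccc(NC(=O)c4cn(-c5ccccc5Cl)nn4)cc3F)ccnc2cc1OCCCN1CCC(C)CC1` gives 130 nM.

Compound 3 carries the lowest number of the three, though compound 2 sits within the usual scatter of it, while compound 1 lies well apart with a higher number. Compound 4 `COc1cc2c(Oc3ccc(NC(=O)c4cn(-c5ccccc5C)nn4)cc3F)ccnc2cc1OCCCN1CCC(C)CC1` is the next step: methyl in place of chloro on an aromatic carbon. Among the measured compounds shown here, no measured step bears on this exact change. For the measured compounds named here, the only step at the same place, a 1.5-fold lower number from compound 2 to compound 3 (0.16 log units; within the scatter), stayed within the scatter, which suggests small substituents there matter little. Compound 1 also carries the methyl group, but it differs from compound 3 in a second place as well, so its higher number cannot be tied to the methyl alone. Taken together, a modest rise in the number is expected for compound 4 in this assay, about a 2.7-fold higher number from compound 3 to compound 4 (0.43 log units; beyond the scatter), with a wide range. Compound 4 is therefore estimated at 350 nM, between 120 nM and 1500 nM.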

Compound 4, half-maximal inhibitory concentration: 2380 nM
For compound 4 the middle estimate is 6.8-fold (0.83 log units) below the measured one; the whole stated range lies below it.
By their numbers in this assay, from the lowest: compounds 3 and 2 (each within the scatter of the next); then compounds 1 and 4 (each within the scatter of the next).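

In this assay, this aromatic carbon proves sensitive to the choice of small group: chloro and methyl each bring one heavy atom, yet exchanging them gives a large step (an 18-fold higher number from compound 3 to compound 4 (1.26 log units; beyond the scatter)). Methyl in place of hydrogen gives a similarly large step (a 13-fold higher number from compound 2 to compound 4 (1.10 log units; beyond the scatter)), so among these three compounds, methyl alone stands apart, while hydrogen and chloro remain within the scatter of each other. The methyl on the saturated ring carbon, by contrast, shows no change beyond the scatter (a 1.8-fold higher number from compound 1 to compound 4 (0.25 log units; within the scatter)), and nothing available gives a cause for the gap between methyl and chloro.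

The compounds shown leave open how other groups on this aromatic carbon, such as methoxy, fluoro or an amine, would read. From the compounds shown here alone, it also remains open whether chloro would keep its lower number without the methyl on the saturated ring.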